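The source may report more compounds than this note shows. Statements on the series, on what has been measured and on what is new or still open speak of the compounds shown alone.

Measured compounds:
Compound 1, `C=CCn1c(=O)/c(=C\c2cccc(Br)c2)[nH]c(=O)/c1=C\c1cccc(Br)c1`, in a functional assay on NCI-H1975 cells (Homo sapiens) for cytotoxicity, read by CCK-8 assay, with a stated time of 72 h (a higher number here means a weaker inhibitor, a lower number a stronger inhibitor), compound 1 gives "not active" (no number reported).
Compound 2, `C=CCn1c(=O)/c(=C\c2ccccc2F)[nH]c(=O)/c1=C\c1ccccc1OC`, in this assay compound 2 gives 25100 nM.
Compound 3, `COc1ccccc1/C=c1/[nH]c(=O)/c(=C\c2nc[nH]c2C(C)(C)C)[nH]c1=O`, in this assay compound 3 gives 100 nM.

Compound 2 stands highest of the two numbers in this assay. The nearest compound, compound 3, sits far lower, and the gap between the two lies well beyond the scatter of the assay. Compound 1 carries no single number, only the report that it is not active, and so it cannot be placed on the same scale.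

Compound 4, `C=CCn1c(=O)/c(=C\c2cc(Br)ccc2F)[nH]c(=O)/c1=C\c1ccccc1OC`, is the next compound to be measured in this assay. It differs from compound 2 in one place: bromo in place of hydrogen on an aromatic carbon. No pair of measured compounds shows this change on its own, so the size of the step cannot be read from a shown step. The best guide is compound 2 itself with its 25100 nM. The added bromo is a single heavy atom on a ring that already carries the fluoro group, and nothing among the shown compounds ties such an addition to a large move in either direction. Compound 4 is therefore expected to remain close to compound 2, with a step of a 1.3-fold lower number from compound 2 to compound 4 (0.10 log units; within the scatter) that is not expected to exceed the scatter. The estimate for compound 4 is 20000 nM, within 6000 nM to 60000 nM.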

Compound 4, half-maximal inhibitory concentration: "not active" (no number reported)
For compound 4 the study gives words and no number; there is nothing to compare the estimate with.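

In this assay, going by these compounds alone, compound 4 gives "not active" (no number reported) and carries no number, so no step from compound 2 to compound 4 can be read. The compounds shown leave open how far the change from 2-fluorophenyl to 5-bromo-2-fluorophenyl moves the value in this assay, and nothing shown here offers an explanation for the result.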